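The compounds below may be only part of what the source reports. "The series", "measured", "known", "first", "only" and "open" are said of these compounds alone.

Compound 2 `Nc1scc(CN2CCN(C3CCCCC3)CC2)c1C(=O)c1ccc(Cl)cc1` gives 1.1 nM in an assay on CHO cells for displacement of a labelled ligand from adenosine receptor A1 (Homo sapiens) (on this read-out higher numbers stand for weaker binding and lower numbers for tighter binding), and compound 1 `CN1CCN(Cc2csc(N)c2C(=O)c2ccc(Cl)cc2)CC1` gives 1.2 nM in this assay; the two values lie within the scatter of each other, so compound 2 stands level with compound 1. Among the compounds with values here, the only measured step that bears on the next change is a 1.1-fold lower number from compound 1 to compound 2 (0.04 log units; within the scatter), which shows that a large group on this ring nitrogen is tolerated. Compound 3 `Nc1scc(CN2CCN(c3ccccc3)CC2)c1C(=O)c1ccc(Cl)cc1` carries phenyl in place of cyclohexyl on an amine nitrogen in a ring. With no step beyond the scatter among the measured compounds, compound 3 is expected to show a 1.5-fold higher number from compound 2 to compound 3 (0.16 log units; within the scatter), estimated at 1.6 nM in this assay, ranging from 0.5 nM to 5 nM.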

Compound 3, dissociation constant: 1 nM
Compound 3: the middle estimate sits 1.6-fold (0.20 log units) above what was measured; measured number inside the range.
By their numbers in this assay, from the lowest: compounds 3, 2 and 1 (each within the scatter of the next).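

With a 1.1-fold lower number from compound 2 to compound 3 (0.04 log units; within the scatter) in this assay and a 1.2-fold lower number from compound 1 to compound 3 (0.08 log units; within the scatter) in the same read-out, phenyl on this amine nitrogen in a ring stands level with both cyclohexyl and methyl. What held for a non-aromatic ring of carbon only at this position therefore also holds for an aromatic one, across these three compounds. No evidence is available that accounts for this level result. Still open, going by these compounds, is whether a carboxylic acid, or a longer chain ending in an amine, would stay level on this nitrogen, and whether a chlorine on the phenyl ring would.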